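The source may report more compounds than this note shows. Statements on the series, on what has been measured and on what is new or still open speak of the compounds shown alone.

Compound 1 `COc1ccc(OCCCON2C(N)=NC(N)=NC23CCOCC3)cc1`: 1670 nM. Compound 2 `NC1=NC2(CCSCC2)N(OCCCOc2cccc(Cl)c2Cl)C(N)=N1`: 30 nM. Compound 3 `NC1=NC2(CCSCC2)N(OCCCOc2ccccc2Br)C(N)=N1`: 180 nM.

In a functional assay on HL-60 cells (Homo sapiens) for antiproliferative activity, read by MTT assay, with a stated time of 72 h (a higher number here means a weaker inhibitor, a lower number a stronger inhibitor), compound 1 stands highest of the three numbers; compound 3 lies nearest and compound 2 furthest, both beyond the scatter. Compound 4 `Cc1ccc(OCCCON2C(N)=NC(N)=NC23CCOCC3)cc1` differs from compound 1 by methyl in place of methoxy on an aromatic carbon. Among the compounds with values here, the only measured step, a 6.0-fold higher number from compound 2 to compound 3 (0.78 log units; beyond the scatter), concerns a different halogen pattern on the phenyl ring and a different core, so it bears on this change only loosely, showing that a change on the aromatic ring can move the number modestly. Within the data shown here, no measured pair exchanges methoxy for methyl. Compound 4 is therefore expected to stay within the scatter of compound 1. The expected step is a 1.1-fold lower number from compound 1 to compound 4 (0.05 log units; within the scatter), none beyond the scatter. Compound 4 is estimated at 1500 nM, between 600 nM and 4000 nM.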

Compound 4, half-maximal inhibitory concentration: 2580 nM
Compound 4: the middle estimate sits 1.7-fold (0.24 log units) below what was measured, and the stated range covers the measured number.
By their numbers in this assay, from the lowest: compound 2; then compound 3; then compounds 1 and 4 (each within the scatter of the next).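

In this assay, the change from 4-methoxyphenyl to 4-methylphenyl gives a 1.5-fold higher number from compound 1 to compound 4 (0.19 log units; within the scatter) with the rest of the molecule held fixed. Within the data shown here, this is the first direct reading at this position, on an aromatic carbon para to a large group, and it shows that methyl can take the place of methoxy without a change beyond the scatter. Nothing measured here explains this result.

On these data alone, whether an amine or a carboxylic acid at this position would leave the number within the scatter remains open. So does whether the same exchange would behave alike on the core of compound 2.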